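Three compounds at the limit, a fourth to estimate

The compounds below may be only part of what the source reports. "The series", "measured", "known", "first", "only" and "open" are said of these compounds alone.

Compound 1 `Cc1ccc(Cn2cc(CSC(=S)N3CCN(C(N)=O)CC3)nn2)cc1`, compound 2 `CCNC(=O)N1CCN(C(=S)SCc2cn(Cc3ccc(C)cc3)nn2)CC1` and compound 3 `COc1ccc(Cn2cc(CSC(=S)N3CCN(C(N)=O)CC3)nn2)cc1` have been tested in a functional assay on MCF7 cells (Homo sapiens) for cytotoxicity, read by MTT assay, with a stated time of 72 h; a lower number here means a stronger inhibitor, a higher number a weaker inhibitor. In this assay compound 1 gives > 128000 nM, which is a limit of the assay and not a number. Compound 2 also gives only a limit, > 128000 nM. Compound 3 likewise gives only a limit, > 128000 nM. All three values therefore sit at the limit of > 128000 nM in this assay, at which 3 of the 3 values shown sit.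

Compound 2 differs from compound 1 by ethyl in place of hydrogen on an amide-type nitrogen; the resulting step that the two limits leave unreadable from compound 1 to compound 2 cannot be read, as both ends are limits. The cores of compound 1 and compound 3 differ by methoxy in place of methyl on an aromatic carbon, and the step that the two limits leave unreadable from compound 1 to compound 3 is unreadable for the same reason.

Compound 4 `CCNC(=O)N1CCN(C(=S)SCc2cn(Cc3ccc(OC)cc3)nn2)CC1` remains to be measured. It differs from compound 3 by ethyl in place of hydrogen on an amide-type nitrogen, the same change as from compound 1 to compound 2, and the surroundings of the place are identical word for word in both. Because compound 1 and compound 2 both stand at the limit of > 128000 nM in this assay, at which 3 of the 3 values shown sit, the step that the limit leaves unreadable from compound 3 to compound 4 is expected to be near zero. Compound 4 is accordingly estimated at 200000 nM, within 100000 nM to 500000 nM, most likely again reported only as a limit.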

Compound 4, half-maximal inhibitory concentration: 97600 nM
Estimate against measurement, compound 4: 2.0-fold (0.31 log units) above; measured number outside the range, below it.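

In this assay, among the compounds shown here, compound 4 gives 97600 nM, the only value that is a number. The values of compound 1, compound 2 and compound 3 are limits of the assay: the limit of > 128000 nM in this assay, at which 3 of the 4 values shown sit.

Ethyl in place of hydrogen on an amide-type nitrogen gives an at least 1.3-fold lower number from compound 3 to compound 4 (0.11 log units; that floor lies within the scatter), and methoxy in place of methyl on an aromatic carbon gives an at least 1.3-fold lower number from compound 2 to compound 4 (0.11 log units; that floor lies within the scatter). The steps with a limit at both ends cannot be read, so the ethyl change on the core of compound 1 has no size to set against the same change on the core of compound 3, and carrying the change from one core to the other is neither confirmed nor ruled out.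

The compounds shown leave open how a propyl or butyl chain in place of ethyl on the amide-type nitrogen would read in this assay. They also leave open how a carboxylic acid in place of methoxy on the aromatic carbon would read there.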